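From Fluoro to Methoxy: Estimating Compound 4

The source may hold more compounds than are shown below. What is called first, only, known or untested is meant among the compounds shown, and "the series" means these compounds.

Measured in a functional assay on Lewis lung carcinoma cells (Mus musculus) for antiproliferative activity, read by MTT assay, with a stated time of 24 h; a higher number here means a weaker inhibitor, a lower number a stronger inhibitor:
- Compound 1 `C=CCc1cc(-c2ccc(OC)cc2)cc(CC=C)c1O`: 60300 nM
- Compound 2 `C=CCc1cc(-c2ccccc2)ccc1O`: > 100000 nM (a limit)
- Compound 3 `C=CCc1cc(-c2ccc(F)cc2)ccc1O`: > 100000 nM (a limit)

Compound 3 has no true number, only the limit > 100000 nM. The series offers little firm ground, with the limit of > 100000 nM in this assay, at which 2 of the 3 values shown sit. Compound 4 `C=CCc1cc(-c2ccc(OC)cc2)ccc1O` has methoxy in place of fluoro on an aromatic carbon, para to a large group: methoxy in place of fluoro on an aromatic carbon. Within the data shown here, the only measured step, a step that the two limits leave unreadable from compound 2 to compound 3, gives no size to carry over. Among the measured compounds shown here, compound 1 also carries methoxy, and in this assay compound 1 gives 60300 nM, the only true number here. A small shift toward stronger inhibition is therefore expected, as the estimated at least 1.1-fold lower number from compound 3 to compound 4 (0.04 log units; that floor lies within the scatter). For compound 4 the estimated value is 90000 nM, with an expected range of 40000 nM to 200000 nM. Compound 4 may also return only a limit.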

Compound 4, half-maximal inhibitory concentration: > 100000 nM
Compound 4 gave a limit, no number; the forecaster's own chance of this, stated with the estimate: 55%; at least 1.1-fold (0.04 log units) between middle value and limit.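

In this assay compound 4 returns only a limit, > 100000 nM, so methoxy on this aromatic carbon, para to a large group, gives no true number. The steps from compound 2 and compound 3 to compound 4 cannot be read, and most of the series now rests on one ceiling: the limit of > 100000 nM in this assay, at which 3 of the 4 values shown sit. Hydrogen in place of allyl is the one readable step, an at least 1.6-fold higher number from compound 1 to compound 4 (0.21 log units; that floor lies within the scatter), so whether that allyl matters remains unsettled.

As far as these compounds go, whether an amine or a carboxylic acid at this same place would give a true number remains open.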